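The source may report more compounds than this note shows. Statements on the series, on what has been measured and on what is new or still open speak of the compounds shown alone.

Compound 1 `Cc1ccc(C(=O)NC2CCCCCC2)c(=O)n1Cc1ccc(F)cc1` yields only a limit in an assay on U-937 cells for inhibition of Fatty-acid amide hydrolase 1 (Homo sapiens), read by scintillation counting, with a stated time of 15 min (on this read-out lower numbers stand for stronger inhibition and higher numbers for weaker inhibition), namely > 10000 nM. Compound 2 `COc1ccc(-c2cc(C(=O)NC3CCCCCC3)c(OCc3ccc(F)cc3)nc2C)cc1` likewise returns a limit in this assay, > 10000 nM. Compound 3 `Cc1nc(OCc2ccc(F)cc2)c(C(=O)NC2CCCCCC2)cc1-c1ccc(F)cc1` also stops at a limit there, > 10000 nM. Among the measured compounds shown here, all three values sit at the limit of > 10000 nM in this assay, at which 3 of the 3 values shown sit, so the one recorded step, a step that the two limits leave unreadable from compound 2 to compound 3, cannot be read in either direction. Compound 4 `Cc1c(Cl)cc(C(=O)NC2CCCCCC2)c(=O)n1Cc1ccc(F)cc1` differs from compound 1 by chloro in place of hydrogen on an aromatic carbon. No measured step touches this change, and none of the shown numbers gives a foothold for movement beyond the scatter. Compound 4 is therefore expected to remain at the limit, with an estimated value of 15000 nM (range 3000 nM to 60000 nM), which would mean an expected step that the limit leaves unreadable from compound 1 to compound 4.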

Compound 4, half-maximal inhibitory concentration: 5900 nM
The estimate for compound 4 lay 2.5-fold (0.41 log units) above the measured number; low and high end bracket the measured number.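

With chloro in place of hydrogen on this aromatic carbon, ortho to a methyl group, the core of compound 1 gives a readable number in this assay, a change of an at least 1.6-fold lower number from compound 1 to compound 4 (0.22 log units; that floor lies within the scatter). Only a floor is known, so the result shows that this position tolerates chloro but does not fix the size of the gain. Compound 4 is the only compound shown with a number rather than a limit: the limit of > 10000 nM in this assay, at which 3 of the 4 values shown sit.

On these data alone, the true distance between compound 1 and compound 4 remains open. So does whether bromo or an amine at this position would give a lower number than chloro.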